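Swapping a nitrile for a methylsulfonyl on a chain

The source may report more compounds than this note shows. Statements on the series, on what has been measured and on what is new or still open speak of the compounds shown alone.

Two compounds have been measured in an assay on isolated protein for binding affinity to leukotriene B4 receptor 1 (Homo sapiens), tested at 1 uM; a lower number here means less inhibition, a higher number more inhibition at the concentration tested (going by the name of the read-out):

Compound 1, `CCCCCc1cc(C(C)=O)c(O)cc1OCCCCC#N`, gives 14%.
Compound 2, `CCc1cc(C(C)=O)c(O)cc1OCCCCCCC(C)(C)C#N`, gives 30%.

Compound 2 stands highest of the two, and its distance from compound 1 lies beyond the usual scatter of this measurement. Compound 3, `CCc1cc(C(C)=O)c(O)cc1OCCCCCCS(C)(=O)=O`, differs from compound 2 in one place: methylsulfonyl in place of 1-cyano-1-methylethyl on a saturated chain carbon, six bonds along the chain from an oxygen on an aromatic ring. No comparable change has been measured here, so the step is expected to be small, downward or none beyond the scatter, with a number 6 percentage points lower from compound 2 to compound 3 (within the scatter) as the expected step. Compound 3 is estimated at 24%, within 5% to 48%.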

Compound 3, a percentage reported as inhibition, at one concentration (the size of the read-out at that concentration, not a potency): 62%
For compound 3 the middle estimate is 38 percentage points below the measured one, outside the stated range (above it).
By their numbers in this assay, from the lowest: compound 1; then compound 2; then compound 3.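

In this assay, the group at the end of this chain clearly counts: methylsulfonyl in place of 1-cyano-1-methylethyl gives a number 32 percentage points higher from compound 2 to compound 3 (beyond the scatter). This is the only change in one place among these compounds, and it shows that a saturated chain carbon, six bonds along the chain from an oxygen on an aromatic ring, is a place where a swap can move inhibition a long way. Nothing available explains the rise. The compounds shown leave open whether the methylsulfonyl itself brings the higher number or the loss of 1-cyano-1-methylethyl does. They also leave open how an amine or a carboxylic acid would fare at this place.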